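Thiazolyl Ketone Replaces Pyrazolyl Ketone on the Shared Core

The source may report more compounds than this note shows. Statements on the series, on what has been measured and on what is new or still open speak of the compounds shown alone.

Measured so far:
compound 1 `CCCCOC(=O)NS(=O)(=O)c1sc(CC(C)C)cc1-c1ccc(Cc2ncco2)cc1` gives 3.9 nM in an assay on membranes from uterus for displacement of a labelled ligand from Angiotensin type II receptor (Sus scrofa), with a stated time of 1.5 h; on this read-out higher numbers stand for weaker inhibition and lower numbers for stronger inhibition
compound 2 `CCCCOC(=O)NS(=O)(=O)c1sc(CC(C)C)cc1-c1ccc(C(=O)c2ccnn2C)cc1` gives 3.4 nM in this assay

Going by the values given here, compound 2 stands at the lowest of the two numbers, but its nearest neighbour is compound 1, and the only measured step, a 1.1-fold lower number from compound 1 to compound 2 (0.06 log units; within the scatter), is within the scatter. That step exchanges the whole group on the aromatic carbon, so it speaks to how much the shared core tolerates at that site rather than to the exact change now in question.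

Compound 3 `CCCCOC(=O)NS(=O)(=O)c1sc(CC(C)C)cc1-c1ccc(C(=O)c2nccs2)cc1` is not yet measured. It differs from compound 2 by 1,3-thiazol-2-yl in place of 1-methyl-1H-pyrazol-5-yl on a carbonyl carbon, with the carbonyl kept in place. Among the compounds with values here, no measured pair shows a five-membered aromatic ring exchanged for another on a carbonyl carbon, so there is no step that bears directly on it. Since compound 1 and compound 2 sit within the scatter of one another despite a larger change, the step of a 1.1-fold higher number from compound 2 to compound 3 (0.05 log units; within the scatter) is expected to stay within the scatter too. Compound 3 is therefore estimated at 3.8 nM, with a range of 1.5 nM to 10 nM.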

Compound 3, inhibition constant: 18.6 nM
Compound 3: middle estimate off by 4.9-fold (0.69 log units), on the low side; the whole stated range lies below it.
By their numbers in this assay, from the lowest: compounds 2 and 1 (each within the scatter of the next); then compound 3.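

The exchange on the carbonyl carbon in this assay proves not to be silent (the step is a 5.5-fold higher number from compound 2 to compound 3 (0.74 log units; beyond the scatter)): with the carbonyl kept in place, this site tells 1,3-thiazol-2-yl from 1-methyl-1H-pyrazol-5-yl, although each is a five-membered aromatic ring with the same counts of hetero atoms, hydrogen-bond donors and hydrogen-bond acceptors. The earlier pair showed only that (1-methyl-1H-pyrazol-5-yl)carbonyl and (1,3-oxazol-2-yl)methyl sit within the scatter of each other, whereas the new comparison (the step is a 4.8-fold higher number from compound 1 to compound 3 (0.68 log units; beyond the scatter)) shows that the aromatic carbon does not accept every such group equally, with (1,3-thiazol-2-yl)carbonyl standing apart as a modest step beyond the scatter. Nothing at hand gives a reason for the higher number of compound 3.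

The compounds shown leave open whether the step follows the ring as a whole, its sulfur atom or the methyl group that leaves with the pyrazole. A plain phenyl ring or an unsubstituted pyrazole on the same carbonyl carbon would be needed to separate these readings, and a single thiazole example cannot say how far the effect extends.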